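A few compounds are considered here, and "the series" means these few. Any claim that something is new, unique, unknown or untested is made for them only; others in the source may bear on it.

Measured compounds:
- compound 1, `COc1cc(C)cc(-c2c(-c3ccnc(-c4ccc(C(C)=O)cc4)c3)cnn2CC#N)c1`: > 100000 nM (a limit)
- compound 2, `Cc1cc(O)cc(-c2nn(CC#N)cc2-c2ccnc(-c3ccc(Oc4ccccc4)cc3)c2)c1`: 9140 nM
- compound 3, `COc1cc(C)cc(-c2nn(CC#N)cc2-c2ccnc(-c3ccc(N(C)C)cc3)c2)c1`: 12400 nM

In a functional assay on ACHN cells (Homo sapiens) for inhibition, read by sulforhodamine B assay, with a stated time of 48 h (a higher number here means a weaker inhibitor of growth, a lower number a stronger inhibitor of growth), compound 1 gives > 100000 nM, which is a limit of the assay rather than a number (the limit of > 100000 nM in this assay, at which 1 of the 3 values shown sits). In this assay compound 2 gives 9140 nM. In this assay compound 3 gives 12400 nM, the higher of the two numbers, though its gap to compound 2 lies within the scatter of repeated measurements, so the two are not distinguished.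

Compound 4, `Cc1cc(O)cc(-c2nn(CC#N)cc2-c2ccnc(-c3ccc(N(C)C)cc3)c2)c1`, has not yet been measured in this assay. Compared with compound 3 it carries hydrogen in place of methyl on an oxygen on an aromatic ring. Going by the values given here, no pair among the measured compounds differs by this change alone, so no measured step tells its size or direction. Compound 2 also bears a hydroxy at this place, yet it differs from compound 3 in a second position as well, and its value and that of compound 3 sit within the scatter of each other.

The step from compound 3 to compound 4 is therefore expected to be small, a 1.4-fold lower number from compound 3 to compound 4 (0.14 log units; within the scatter), with no clear direction beyond the scatter. Compound 4 is estimated to give 9000 nM in this assay, within a range from 3000 nM to 30000 nM.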

Compound 4, concentration for total growth inhibition: 23700 nM
The estimate for compound 4 lay 2.6-fold (0.42 log units) below the measured number; the range from low to high includes it.
By their numbers in this assay, from the lowest: compounds 2, 3 and 4 (each within the scatter of the next, the first and the last beyond it). At a limit, above all of these: compound 1.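

The replacement of methoxy by hydroxy, as 3-methoxy-5-methylphenyl becomes 3-hydroxy-5-methylphenyl, can now be read on its own, and in this assay it gives a 1.9-fold higher number from compound 3 to compound 4 (0.28 log units; within the scatter); with dimethylamino held constant, this change on the oxygen is therefore not told apart from the scatter of repeated measurements. Going by these compounds alone, with the hydroxy held constant, the other change gives a 2.6-fold higher number from compound 2 to compound 4 (0.41 log units; beyond the scatter), so dimethylamino in place of phenoxy on an aromatic carbon produces a modest step that can be distinguished from the scatter, something the earlier compounds could not show, since none of them formed a pair differing in one place. Nothing among the data shown gives a reason for the size of either step.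

Going by these compounds, it remains open whether methoxy and hydroxy also read alike when phenoxy stands in place of dimethylamino, and whether an amine, a carboxylic acid or a longer chain such as ethoxy at the same place would move the number beyond the scatter. On these data alone, it is also open whether groups such as morpholine, on the aromatic carbon that carries phenoxy or dimethylamino, would extend the modest step seen there.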